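This account rests on a few compounds, and the source may have more. Where it says the series, first, only, none or still open, it means among the compounds named here.

Measured in a functional assay on HCT-116 cells (Homo sapiens) for inhibition, read by CCK-8 assay, with a stated time of 48 h; on this read-out lower numbers stand for stronger inhibition and higher numbers for weaker inhibition:
Compound 1 `CCN1CCN(CC(=O)N(Cc2ccc(OC)cc2)c2cc(OC)c(OC)c(OC)c2)CC1`: > 20000 nM (a limit)
Compound 2 `COc1ccc(CN(C(=O)CN2CCN(C(C)=O)CC2)c2cc(OC)c(OC)c(OC)c2)cc1`: > 20000 nM (a limit)

Compound 2 stands only at a limit, > 20000 nM. Both measured compounds sit there, as the limit of > 20000 nM in this assay, at which 2 of the 2 values shown sit, records. Compound 3 `COc1ccc(CN(C(=O)CN2CCN(C(=O)OC(C)(C)C)CC2)c2cc(OC)c(OC)c(OC)c2)cc1` carries the change (tert-butoxy in place of methyl on a carbonyl carbon). For the measured compounds named here, the one measured step that bears on it, a step that the two limits leave unreadable from compound 1 to compound 2, gives no readable size, so it offers no measured guide to size or direction. No clear gain in this assay is therefore expected. The expected step is a number no higher from compound 2 to compound 3 (the limit leaves the size open). For compound 3 the estimated value is 20000 nM, with an expected range of 7000 nM to 40000 nM.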

Compound 3, half-maximal inhibitory concentration: 18100 nM
Compound 3: middle estimate off by 1.1-fold (0.04 log units), on the high side; measured number inside the range.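

With tert-butoxy in place of methyl on a carbonyl carbon, this assay gives a number for compound 3 rather than a limit. The change amounts to an at least 1.1-fold lower number from compound 2 to compound 3 (0.04 log units; that floor lies within the scatter), and replacing ethyl on the amine nitrogen in a ring with tert-butoxycarbonyl amounts to an at least 1.1-fold lower number from compound 1 to compound 3 (0.04 log units; that floor lies within the scatter). Neither floor fixes a size, and the other two compounds remain limits: the limit of > 20000 nM in this assay, at which 2 of the 3 values shown sit.

On these data alone, it stays open whether a carboxylic acid or a longer chain in place of tert-butoxy on this carbonyl carbon would carry the number clearly beyond the scatter.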